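Swapping an amine chain for a triazole diol

A few compounds are considered here, and "the series" means these few. Any claim that something is new, unique, unknown or untested is made for them only; others in the source may bear on it.

Compound 2 `CN(C)CCCCCn1c2c(c3ccccc31)C(=O)c1c[n+]([O-])c3ccccc3c1C2=O`: 370 nM
Compound 1 `CC1(C)OC[C@@H](Cn2cc(Cn3c4c(c5ccccc53)C(=O)c3c[n+]([O-])c5ccccc5c3C4=O)nn2)O1`: > 1000 nM

Within the data shown here, in a functional assay on SH-SY5Y cells (Homo sapiens) for cytotoxicity, read by MTT assay, with a stated time of 72 h (on this read-out higher numbers stand for weaker inhibition and lower numbers for stronger inhibition), compound 2 gives 370 nM, the only plain number among the two values shown. Compound 1 is reported only as a limit, > 1000 nM, and (the limit of > 1000 nM in this assay, at which 1 of the 2 values shown sits).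

Compound 3 `O=C1c2c[n+]([O-])c3ccccc3c2C(=O)c2c1c1ccccc1n2Cc1cn(C[C@H](O)CO)nn1` is not yet measured. It differs from compound 2 in one place: 1-(2,3-dihydroxypropyl)-1H-1,2,3-triazol-4-yl in place of 4-(dimethylamino)butyl on a saturated chain carbon bound to an aromatic nitrogen. Among the measured compounds shown here, no step between two measured compounds is available to calibrate this change, so the expectation rests on compound 1, which also carries a triazole ring on the same chain carbon and gives only the limit > 1000 nM. On that basis compound 3 is expected to be weaker than compound 2, with an estimated step of a 4.1-fold higher number from compound 2 to compound 3 (0.61 log units; beyond the scatter) that goes beyond the usual scatter. The estimate for compound 3 in this assay is 1500 nM, within a range of 500 nM to 5000 nM, with a real chance that only a limit is reported.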

Compound 3, half-maximal inhibitory concentration: > 1000 nM
Compound 3 ended at the assay's limit; the forecaster's own chance of this, stated with the estimate: 60%; the middle value lies beyond the limit too.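

In this assay, among these compounds, putting 1-(2,3-dihydroxypropyl)-1H-1,2,3-triazol-4-yl in place of 4-(dimethylamino)butyl on a saturated chain carbon bound to an aromatic nitrogen gives an at least 2.7-fold higher number from compound 2 to compound 3 (0.43 log units; beyond the scatter), the first step at this position that can be read. From the compounds shown here alone, the value of compound 3, > 1000 nM, is a limit of the assay and not a number, so the full size of this step stays unknown. The step from 2,2-dimethyl-1,3-dioxolan-4-yl to 1,2-dihydroxyethyl on the triazole side chain cannot be read, since compound 1 and compound 3 both end at the same limit: the limit of > 1000 nM in this assay, at which 2 of the 3 values shown sit.

Going by these compounds, it remains open whether the triazole ring or the missing dimethylamino group accounts for the weaker result. A triazole side chain ending in a dimethylamino group in place of the diol would separate the two, and a longer amine chain would show how much the chain length matters.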